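The source may hold more compounds than are shown below. What is called first, only, known or untested is meant among the compounds shown, and "the series" means these compounds.

In an in vitro ADME assay on microsomes from liver (Homo sapiens) for pharmacokinetics, read by LC-MS, with a stated time of 10 min, tested at 1 uM (on this read-out lower numbers stand for slow clearance and higher numbers for fast clearance), the compounds measured so far:

- compound 1 `Cc1ccc(NC(=O)[C@H]2CN(C)C[C@@H]2c2ccc(/C=C/C(=O)Nc3ccccc3N)cc2)cc1`: 15 mL/min/kg
- compound 2 `CN1C[C@H](C(=O)Nc2ccc(C#N)cc2)[C@@H](c2ccc(/C=C/C(=O)Nc3ccccc3N)cc2)C1`: 1 mL/min/kg

Going by the values given here, compound 2 holds the lower of the two numbers, at 1 mL/min/kg, and compound 1 is its only measured neighbour. The next step leads to compound 3 `CN1C[C@H](C(=O)Nc2ccc(C(F)(F)F)cc2)[C@@H](c2ccc(/C=C/C(=O)Nc3ccccc3N)cc2)C1`, with trifluoromethyl in place of cyano on an aromatic carbon, para to a large group (trifluoromethyl in place of cyano on an aromatic carbon).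

Among the compounds with values here, one measured step bears on this: a 15-fold lower number from compound 1 to compound 2 (1.18 log units; beyond the scatter), a large change with cyano in place of methyl on the same aromatic carbon. It shows that this assay can respond strongly to a change at this carbon. Within the data shown here, the data hold no measured compound with trifluoromethyl, and one step sets no trend. Among the measured compounds shown here, the only measured compound without cyano here is compound 1, at 15 mL/min/kg, so a rise is expected on leaving cyano, though a smaller one than that measured step. The expected change is a 5.0-fold higher number from compound 2 to compound 3 (0.70 log units; beyond the scatter), and this estimate is loose. For compound 3 the estimated clearance is 5 mL/min/kg, with an expected range of 1.5 mL/min/kg to 15 mL/min/kg.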

Compound 3, clearance: 6 mL/min/kg
Compound 3: middle estimate off by 1.2-fold (0.08 log units), on the low side; the range from low to high includes it.
By their numbers in this assay, from the lowest: compound 2; then compound 3; then compound 1.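

In this assay this aromatic carbon now carries three different groups, and all three read apart: trifluoromethyl in place of the nitrile gives (a 6.0-fold higher number from compound 2 to compound 3 (0.78 log units; beyond the scatter)), while trifluoromethyl in place of methyl gives (a 2.5-fold lower number from compound 1 to compound 3 (0.40 log units; beyond the scatter)). The low number of compound 2 therefore does not come with every replacement of methyl, since compound 3 keeps only part of that drop and sits between the other two, each of its steps lying beyond the scatter. Across these three compounds the read-out at this position is graded rather than split in two, running from the nitrile of compound 2 through the trifluoromethyl of compound 3 to the methyl of compound 1, but nothing on hand accounts for that order.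

As far as these compounds go, whether the order extends to other groups on this carbon, such as chlorine, methoxy, an amine or a carboxylic acid, remains open. Also open, from the compounds shown here alone, is whether the same ranking of nitrile, trifluoromethyl and methyl would hold with a change elsewhere on the shared core.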